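Oxadiazole amidoxime series: phenyl replaced by guanidine-type group

The source may report more compounds than this note shows. Statements on the series, on what has been measured and on what is new or still open speak of the compounds shown alone.

Measured in an assay on isolated protein for antagonist activity at cytohesin-3 (Mus musculus), read by surface plasmon resonance, with a stated time of 30 min, tested at 50 uM; on this read-out higher numbers stand for more inhibition at the one concentration tested (going by the name of the read-out) and lower numbers for less inhibition:
- compound 1 `N=C(N/C(=N/O)c1nonc1N)c1ccccc1N`: 59%
- compound 2 `N=C(N/C(=N/O)c1nonc1N)c1ccccc1`: 55%

Compound 2 has the lowest of the two numbers, though the step of a number 4 percentage points lower from compound 1 to compound 2 (within the scatter) is within the scatter, so the two compounds are not separated. Compound 3 `N=C(N)NC(=N)N/C(=N/O)c1nonc1N` differs from compound 2 by a group of 4 heavy atoms (1 carbon, 3 nitrogen; no ring) in place of a group of 6 heavy atoms (6 carbon; one six-membered aromatic ring of carbon only), on a carbon with a double bond to nitrogen. Going by the values given here, no measured step bears on this change; the only step seen, hydrogen for amino, was small. With nothing to anchor it, compound 3 is expected to fall somewhat lower, a step of a number 10 percentage points lower from compound 2 to compound 3 (within the scatter) being the estimate. In this assay compound 3 is thus estimated at 45%, within 20% to 70%.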

Compound 3, a percentage reported as inhibition, at one concentration (the size of the read-out at that concentration, not a potency): 56%
Beside the measured number, compound 3's estimate is 11 percentage points below it; measured number inside the range.
By their numbers in this assay, from the lowest: compounds 2, 3 and 1 (each within the scatter of the next).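

In this assay putting the acyclic group of 4 heavy atoms in place of phenyl, on a carbon with a double bond to nitrogen, gives a number 1 percentage points higher from compound 2 to compound 3 (within the scatter) and so leaves the two compounds unseparated. An aromatic ring of carbon at this position is therefore not required for this level of inhibition, at least between these two compounds. No available evidence explains why the two groups read alike.

Still open, on these data alone, is how a methyl, a primary amine or a cyclohexyl group would read on this carbon. Also open, as far as these compounds go, is whether compounds reading alike at one concentration would also match in potency.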